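Swapping the allyl oxime ether for a methoxypropyl chain

The source may report more compounds than this note shows. Statements on the series, on what has been measured and on what is new or still open speak of the compounds shown alone.

Three compounds that share one core and differ only in the group on the oxime oxygen have been measured in a physicochemical assay for lipophilicity, using the shake flask method; on this read-out lower numbers stand for lower lipophilicity and higher numbers for higher lipophilicity. Compound 1 `C=CCO/N=C/c1c(N)ncnc1Oc1ccc(NC(=O)C2(C(=O)Nc3ccc(F)cc3)CC2)cc1F` gives 3.65. Compound 2 `Nc1ncnc(Oc2ccc(NC(=O)C3(C(=O)Nc4ccc(F)cc4)CC3)cc2F)c1/C=N/O` gives 2.62, and compound 3 `Nc1ncnc(Oc2ccc(NC(=O)C3(C(=O)Nc4ccc(F)cc4)CC3)cc2F)c1/C=N/OC1CCCC1` gives 4.27. Compound 1 stands second highest of the three: its nearest neighbour is compound 3, reached by a number 0.62 log units higher from compound 1 to compound 3 (beyond the scatter), and its furthest is compound 2, reached by a number 1.03 log units lower from compound 1 to compound 2 (beyond the scatter); the full span from the smallest to the largest group is a number 1.65 log units higher from compound 2 to compound 3 (beyond the scatter).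

Compound 4 `COCCCO/N=C/c1c(N)ncnc1Oc1ccc(NC(=O)C2(C(=O)Nc3ccc(F)cc3)CC2)cc1F` is not yet measured in this assay. It differs from compound 1 as follows: 2-methoxyethyl in place of vinyl on a saturated chain carbon bound to an oxygen on an unsaturated carbon. All three measured steps bear on it, since each changes only the group on the same oxygen, and each moved the read-out beyond the scatter, the larger ones when the group changed most in size. Here the chain grows by two heavy atoms but gains one hydrogen-bond acceptor, so a modest step downward is expected, a number 0.40 log units lower from compound 1 to compound 4 (beyond the scatter). Compound 4 is therefore estimated at 3.25, within a range of 2.8 to 3.7.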

Compound 4, partition coefficient: 3.18
Beside the measured number, compound 4's estimate is 0.07 log units above it, within the range that was stated.
By their numbers in this assay, from the lowest: compound 2; then compound 4; then compound 1; then compound 3.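

In this assay, within the data shown here, the 3-methoxypropyl chain is the first group on this oxygen to break the order seen so far, in which the number rose with the size of the group: although larger than allyl, it gives a number 0.47 log units lower from compound 1 to compound 4 (beyond the scatter). The chain also leaves compound 4 clearly apart from both ends of the series, with a number 0.56 log units higher from compound 2 to compound 4 (beyond the scatter) and a number 1.09 log units lower from compound 3 to compound 4 (beyond the scatter), so a larger group on this oxygen can give a number under that of compound 1. Nothing measured here accounts for these steps.

The compounds shown leave open whether the ether oxygen or the chain itself sets the step, since a plain pentyl chain on the same oxygen would separate the two. They also leave open how a chain ending in an amine or a carboxylic acid would read in this assay.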